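Aryl ether to aryl thioether on the shared core

The compounds below may be only part of what the source reports. "The series", "measured", "known", "first", "only" and "open" are said of these compounds alone.

Among the measured compounds shown here, compound 1 `Nc1cc(N)c2nc(-c3ccccc3)c(Oc3ccc(Cl)c(Cl)c3)nc2c1` is the only member of the series with a numeric result in a functional assay on LOX IMVI cells (Homo sapiens) for inhibition, read by sulforhodamine B assay, with a stated time of 48 h (a lower number here means a stronger inhibitor of growth, a higher number a weaker inhibitor of growth), where compound 1 gives 16200 nM. Compound 2 `CCOC(=O)[C@H](CCC(=O)O)NC(=O)c1ccc(CNc2nc3cc(N)cc(N)c3nc2-c2ccccc2)cc1` carries the longer amide-linked chain on the same core; in this assay compound 2 gives < 100000 nM, which is a limit of the assay rather than a number. With one number and one limit, compound 1 stands as the only fixed point on which any comparison can rest, and the limit of < 100000 nM in this assay, at which 1 of the 2 values shown sits, is the whole of the evidence beyond it.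

Compound 3 `Nc1cc(N)c2nc(-c3ccccc3)c(Sc3ccc(F)cc3)nc2c1` differs from compound 1 in one place: (4-fluorophenyl)sulfanyl in place of 3,4-dichlorophenoxy on an aromatic carbon. For the measured compounds named here, no pair of measured compounds follows this change, so there is no measured step to lean on. The replacement swaps one aromatic substituent for another of similar size in the same place, and the expectation is a step from compound 1 to compound 3 of a 1.2-fold higher number from compound 1 to compound 3 (0.09 log units; within the scatter), within the usual scatter. Compound 3 is therefore estimated at 20000 nM, with a range from 5000 nM to 80000 nM.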

Compound 3, concentration for 50% growth inhibition: 22900 nM
Compound 3: middle estimate off by 1.1-fold (0.06 log units), on the low side; measured number inside the range.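

Among the compounds shown here, replacing 3,4-dichlorophenoxy with (4-fluorophenyl)sulfanyl on this aromatic carbon gives, in this assay, a 1.4-fold higher number from compound 1 to compound 3 (0.15 log units; within the scatter) and thus provides the first measured step at this position: the two groups are not separated in this read-out. The change is compound, since the linking oxygen gives way to sulfur and the chlorine atoms give way to fluorine in the same step, so this single step cannot assign any share of the result to either part; it shows only that the two parts taken together leave the number within the scatter. Nothing measured in the series gives a cause for this result.

Still open, from the compounds shown here alone, is whether the linking atom and the halogen pattern each leave the number unchanged or whether two separate effects happen to offset each other, a question that only a thioether carrying 3,4-dichlorophenyl or an ether carrying 4-fluorophenyl could settle. Also open, going by these compounds, is how this position responds to a group of a different kind, such as a morpholine or a piperazine, in place of the aryl ether or thioether.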